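Swapping an Amide for a Urea on a Potent Melatonin Ligand

The compounds below may be only part of what the source reports. "The series", "measured", "known", "first", "only" and "open" are said of these compounds alone.

Compound 1 `CCC(=O)NCC1CCc2c(OC)cccc2N1C` binds tightly: in an assay on CHO cells for displacement of a labelled ligand from melatonin receptor type 1A (Homo sapiens), with a stated time of 120 min (a lower number here means a stronger inhibitor, a higher number a weaker inhibitor), compound 1 gives 0.03 nM. Compound 2 `CCC(=O)NCCC1CCc2ccccc2N1Cc1ccccc1`, which differs from it in several places at once, gives 326 nM in this assay, a far higher number, so compound 1 stands lowest of the two. Compound 3 `CCNC(=O)NCC1CCc2c(OC)cccc2N1C` has not yet been measured. It differs from compound 1 in one place: ethylamino in place of ethyl on a carbonyl carbon. Going by the values given here, no single-change step between measured compounds is known, so nothing measured sets the size of this one. The expected step of a 33-fold higher number from compound 1 to compound 3 (1.52 log units; beyond the scatter) is a moderate rise in the number, beyond the scatter. Compound 3 is expected to give about 1 nM, within 0.1 nM to 10 nM.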

Compound 3, inhibition constant: 5 nM
Compound 3: middle estimate off by 5.0-fold (0.70 log units), on the low side; measured number inside the range.
By their numbers in this assay, from the lowest: compound 1; then compound 3; then compound 2.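

Going by these compounds alone, this is the first single-change step measured at this position, and it is large: in this assay, ethylamino in place of ethyl on a carbonyl carbon gives a 170-fold higher number from compound 1 to compound 3 (2.22 log units; beyond the scatter). The swap of a few atoms, which adds one nitrogen and one hydrogen-bond donor, therefore matters greatly here, although compound 3 still gives a low number at 5 nM. No measurement at hand explains the size of this step. From the compounds shown here alone, it remains open whether the rise follows the added nitrogen alone or also depends on the chain beyond it, as methylamino, propylamino or ethoxy on the same carbonyl carbon would show.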